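From 4-nitrophenyl to 2H-indazol-6-yl on the shared core

The source may report more compounds than this note shows. Statements on the series, on what has been measured and on what is new or still open speak of the compounds shown alone.

In a functional assay on K562 cells (Homo sapiens) for inhibition (on this read-out higher numbers stand for weaker inhibition and lower numbers for stronger inhibition), compound 1 (`CCOc1ccc(Cl)cc1-c1cc(Nc2ccc(CCCO)cc2)nc(N)n1`) gives > 1000 nM, which is a limit of the assay. Going by the values given here, compound 2 (`CCOc1ccc(Cl)cc1-c1cc(Nc2ccc([N+](=O)[O-])cc2)nc(N)n1`) gives 180 nM, the only actual number so far. Among the compounds with values here, the one measured step, an at least 5.5-fold lower number from compound 1 to compound 2 (0.74 log units; beyond the scatter), shows that this part of the structure can move the read-out. From the compounds shown here alone, that step starts from the limit of > 1000 nM in this assay, at which 1 of the 2 values shown sits, so its true size remains open.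

Compound 3 (`CCOc1ccc(Cl)cc1-c1cc(Nc2ccc3c[nH]nc3c2)nc(N)n1`) carries a larger change, 2H-indazol-6-yl in place of 4-nitrophenyl on a nitrogen on an aromatic ring: 2H-indazol-6-yl replaces 4-nitrophenyl on a nitrogen on an aromatic ring. The step of an at least 5.5-fold lower number from compound 1 to compound 2 (0.74 log units; beyond the scatter) exchanged only a group on that ring and therefore gives no firm guide to the size or direction of this replacement. No clear shift is expected in this assay, and the expected change is a 1.1-fold higher number from compound 2 to compound 3 (0.05 log units; within the scatter). For compound 3 the estimate is 200 nM, with an expected range of 40 nM to 1000 nM.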

Compound 3, half-maximal inhibitory concentration: < 100 nM
Compound 3 gave a limit, no number; the forecaster's own chance of this, stated with the estimate: 12%; at least 2.0-fold (0.30 log units) between middle value and limit.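

In this assay, putting 2H-indazol-6-yl in place of 4-nitrophenyl on a nitrogen on an aromatic ring gives an at least 1.8-fold lower number from compound 2 to compound 3 (0.25 log units; that floor lies within the scatter). Where the earlier step exchanged only a group on that ring, this one shows that the whole ring can be replaced by a fused pair of aromatic rings with a hydrogen-bond donor while the number does not rise. The value of compound 3, < 100 nM, is a limit of the assay and not a number, so the true size of the step remains open: the limit of < 100 nM in this assay, at which 1 of the 3 values shown sits.

The compounds shown leave open whether the hydrogen on the ring nitrogen of 2H-indazol-6-yl matters to the read-out, as its methyl counterpart would test. They also leave open how an amine or a carboxylic acid would read in place of the nitro group of compound 2.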